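The source may hold more compounds than are shown below. What is called first, only, known or untested is meant among the compounds shown, and "the series" means these compounds.

Notes on the series. Among the measured compounds shown here, compound 1 `Cc1cc(C)c(CN2CCc3c(Cl)cc([C@@H](CO)[C@@H]4CCCO4)c(Cl)c3C2=O)c(=O)[nH]1` is the only member with a single number in an assay for inhibition of histone-lysine N-methyltransferase EZH2 variant Y641N (Homo sapiens), read by scintillation counting, with a stated time of 60 min, in the presence of a further agent that is not named here; a lower number here means a stronger inhibitor, a higher number a weaker inhibitor: compound 1 gives 135 nM. Compound 2 `COC(c1cc(Cl)c2c(c1Cl)C(=O)N(Cc1c(C)cc(C)[nH]c1=O)CC2)C1CCN(C2COC2)CC1` also appears in this assay, where compound 2 gives 530 nM; 0.64 nM (2 entries). For the measured compounds named here, the spread among those entries, (the several entries of compound 2 in this assay, 530 nM; 0.64 nM (2 entries)), is too wide for compound 2 to serve as an anchor, and no step between measured compounds can be drawn from it. Compound 3 `Cc1cc(C)c(CN2CCc3c(Cl)cc([C@@H](CO)[C@H]4CCCO4)c(Cl)c3C2=O)c(=O)[nH]1` is the next member to be measured in this assay. From compound 1 it differs as follows: the two compounds have the same atoms and bonds and differ only in configuration as drawn: 1 of 2 stereo elements differ; a stereocentre at a saturated ring carbon is drawn S in compound 1 and R in compound 3. Going by the values given here, no measured pair shows what inverting configuration at a saturated ring carbon does here, so the change could move potency in either direction. The expectation leans toward a weaker result, with a step of a 2.4-fold higher number from compound 1 to compound 3 (0.37 log units; beyond the scatter) expected. Compound 3 is expected at about 320 nM, within 60 nM to 1600 nM.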

Compound 3, inhibition constant: 110 nM
Estimate against measurement, compound 3: 2.9-fold (0.46 log units) above, and the stated range covers the measured number.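

In this assay the series now has a readable step, and a 1.2-fold lower number from compound 1 to compound 3 (0.09 log units; within the scatter) shows that the S and R drawings at this saturated ring carbon are not told apart. This result can be tied to that single stereocentre, with nothing else in the structure changing: the fact that compounds 1 and 3 differ only in the configuration as drawn. Compound 2 could not have shown this, and it still gives no reference level for the series: the several entries of compound 2 in this assay, 530 nM; 0.64 nM (2 entries).

Going by these compounds, whether inverting the other stereo element would prove equally silent remains open, since both compounds share its drawn configuration. Also open, on these data alone, is whether a carboxylic acid on the saturated ring bearing this stereocentre would keep potency in the range of compound 1 and compound 3, or whether configuration at this carbon would then begin to count.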